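Benzothiazole amide series: ring replacement in HCT-116 growth assay

This account rests on a few compounds, and the source may have more. Where it says the series, first, only, none or still open, it means among the compounds named here.

Measured so far:
compound 1 `O=C(CCCCCCNC(=O)C(O)(O)C(F)(F)F)Nc1nc2ccccc2s1`: 2370 nM
compound 2 `COc1ccc2nc(NC(=O)CCCCCCNC(=O)C(O)(O)C(F)(F)F)sc2c1`: 7560 nM
compound 3 `O=C(CCCCCCNC(=O)C(O)(O)C(F)(F)F)Nc1nc2ccc(Cl)cc2s1`: 11000 nM

In a functional assay on HCT-116 cells (Homo sapiens) for inhibition, read by colorimetric assay, with a stated time of 3 days (on this read-out higher numbers stand for weaker inhibition and lower numbers for stronger inhibition), compound 1 gives the lowest number of the three. Changing the aromatic part of the shared core has so far only raised the number: a 3.2-fold higher number from compound 1 to compound 2 (0.50 log units; beyond the scatter) and a 4.6-fold higher number from compound 1 to compound 3 (0.67 log units; beyond the scatter), both beyond the scatter, while the gap between compound 2 and compound 3 is a 1.5-fold higher number from compound 2 to compound 3 (0.16 log units; within the scatter).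

Compound 4 `O=C(CCCCCCNC(=O)C(O)(O)C(F)(F)F)Nc1c(F)cc(F)cc1F` is not yet measured. It differs from compound 1 in one place, (2,4,6-trifluorophenyl in place of 1,3-benzothiazol-2-yl on an amide-type nitrogen). Among the compounds with values here, no measured step covers this exchange; the two steps that come nearest, from compound 1 to compound 2 and from compound 1 to compound 3, alter the same aromatic region by a single group and each weakened inhibition modestly. Replacing the whole group, and with it both hydrogen-bond acceptors, is a larger change than either, so a step at least as large and in the same direction is expected in this assay, with wide uncertainty because nothing comparable has been tested.

Compound 4 is therefore estimated at 8000 nM, between 2500 nM and 30000 nM. That estimate means a step of a 3.4-fold higher number from compound 1 to compound 4 (0.53 log units; beyond the scatter), expected to weaken inhibition.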

Compound 4, half-maximal inhibitory concentration: 22200 nM
For compound 4 the middle estimate is 2.8-fold (0.44 log units) below the measured one, and the stated range covers the measured number.
By their numbers in this assay, from the lowest: compound 1; then compounds 2, 3 and 4 (each within the scatter of the next, the first and the last beyond it).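

In this assay, within the data shown here, the exchange of 1,3-benzothiazol-2-yl for 2,4,6-trifluorophenyl on the amide-type nitrogen gives a 9.4-fold higher number from compound 1 to compound 4 (0.97 log units; beyond the scatter), the first reading of a change to the whole group there rather than a single added group. The entering group has the same count of heavy atoms as the one it replaces, so matching that count does not preserve the number of compound 1, which now stays lowest by a margin beyond the scatter against all three other compounds, with none of them going against this. The exchange removes both hydrogen-bond acceptors and the five-membered ring and adds three fluorines at once, and no available evidence bears on which of these accounts for the step.

Still open, on these data alone, is how a plain phenyl group or a pyridyl group on the same amide-type nitrogen would read, which would help separate the contributions of the fluorines, the ring count and the acceptors. Also open, as far as these compounds go, is whether an amine or a carboxylic acid on the aromatic part of compound 1, or a shorter chain, would lower the number rather than raise it.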